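Moving from a hydroxy-ether chain to a carboxyethyl group

This account rests on a few compounds, and the source may have more. Where it says the series, first, only, none or still open, it means among the compounds named here.

Measured compounds in an assay (Cricetulus griseus) for inhibition of aldehyde dehydrogenase, mitochondrial (Homo sapiens); a lower number here means a stronger inhibitor, a higher number a weaker inhibitor:
compound 1, `C=CCOc1ccc2c(=O)c(-c3ccc(O)cc3)coc2c1`, gives 180 nM
compound 2, `C=CCCCCOc1ccc2c(=O)c(-c3ccc(O)cc3)coc2c1`, gives 150 nM
compound 3, `O=c1c(-c2ccc(O)cc2)coc2cc(OCCOCCOCCO)ccc12`, gives 40 nM

Compound 3 stands lowest of the three numbers in this assay; its nearest neighbour is compound 2, with a 3.8-fold lower number from compound 2 to compound 3 (0.57 log units; beyond the scatter), and the furthest is compound 1, with a 4.5-fold lower number from compound 1 to compound 3 (0.65 log units; beyond the scatter). Within the chain compounds, a 1.2-fold lower number from compound 1 to compound 2 (0.08 log units; within the scatter) shows that lengthening the unsaturated chain alone changes little.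

The unmeasured compound 4, `CC(Oc1ccc2c(=O)c(-c3ccc(O)cc3)coc2c1)C(=O)O`, differs from compound 3 at the same position: 1-carboxyethyl in place of 2-(2-(2-hydroxyethoxy)ethoxy)ethyl on an oxygen on an aromatic ring. For the measured compounds named here, the steps that bear on this are those into compound 3, a 4.5-fold lower number from compound 1 to compound 3 (0.65 log units; beyond the scatter) and a 3.8-fold lower number from compound 2 to compound 3 (0.57 log units; beyond the scatter), both modest gains tied to the 2-(2-(2-hydroxyethoxy)ethoxy)ethyl chain. Going by the values given here, compound 4 gives that chain up for a short 1-carboxyethyl group, for which no measured step exists, so the expectation is that the gain seen for compound 3 is largely surrendered, returning toward the level of compound 1 and compound 2 in this assay.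

Compound 4 is therefore expected at 150 nM, within a range of 50 nM to 500 nM, which would mean an estimated step of a 3.8-fold higher number from compound 3 to compound 4 (0.57 log units; beyond the scatter).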

Compound 4, half-maximal inhibitory concentration: 2500 nM
Compound 4: the middle estimate sits 17-fold (1.22 log units) below what was measured, outside the stated range (above it).
By their numbers in this assay, from the lowest: compound 3; then compounds 2 and 1 (each within the scatter of the next); then compound 4.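

In this assay, for the compounds shown here, the substituent on an oxygen on an aromatic ring proves able to shift the number much further than the earlier compounds showed, since their steps were modest at most, whereas 1-carboxyethyl in place of 2-(2-(2-hydroxyethoxy)ethoxy)ethyl gives a 63-fold higher number from compound 3 to compound 4 (1.80 log units; beyond the scatter). This is more than the gain of compound 3 being given back. The short acid-bearing group also falls well short of both unsaturated chains, with a 17-fold higher number from compound 2 to compound 4 (1.22 log units; beyond the scatter) and a 14-fold higher number from compound 1 to compound 4 (1.14 log units; beyond the scatter), which makes compound 4 the weakest inhibitor of the four. Nothing shown here explains why this change costs so much.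

The compounds shown leave open whether the loss belongs to the carboxylic acid itself or to the methyl branch of the 1-carboxyethyl group, a question that an unbranched carboxymethyl group, a methyl ester or a longer chain ending in a carboxylic acid could address. As far as these compounds go, it also remains open whether the gain of compound 3 depends on its terminal hydroxyl or on its ether oxygens, which a methyl-capped version of the same chain could help to separate.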